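The source may hold more compounds than are shown below. What is called first, only, known or untested is meant among the compounds shown, and "the series" means these compounds.

For the measured compounds named here, compound 2 `CCNC(=O)CC1CCc2cc(OC)c(OC)cc21` is one of two compounds measured in a functional assay on the whole organism (strain Wistar) for inhibition, with Rattus norvegicus as the target, read by paw edema, with stated times of 60 min and 24 h, at a dose of 100 mg/kg by the oral route (a higher number here means more inhibition at the dose given (going by the name of the read-out), a lower number less inhibition), where compound 2 gives 33.3%. The other is compound 1 `COc1cc2c(cc1OC)C(CC(N)=O)CC2`, which in this assay gives 26.7%. The two are separated only by a number 6.6 percentage points higher from compound 1 to compound 2 (within the scatter), so on the numbers shown compound 2 stands level with compound 1 rather than apart from it. Compound 3 `COc1cc2c(cc1OC)C(CC(=O)NC(C)(C)C)CC2` is the next step from compound 2: tert-butyl in place of ethyl on an amide-type nitrogen. Going by the values given here, the one measured step that bears on this change is the earlier one on the same nitrogen, a number 6.6 percentage points higher from compound 1 to compound 2 (within the scatter), and it stayed within the scatter. On that basis the step in this assay from compound 2 to compound 3 is expected to be a number 0.3 percentage points lower from compound 2 to compound 3 (within the scatter), with no change beyond the scatter in either direction. Compound 3 is therefore estimated at 33%, between 20% and 46%.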

Compound 3, a percentage reported as inhibition, in the whole organism at one dose (the size of the read-out at that dose, not a potency): 40%
For compound 3 the middle estimate is 7 percentage points below the measured one, within the range that was stated.
By their numbers in this assay, from the lowest: compounds 1, 2 and 3 (each within the scatter of the next, the first and the last beyond it).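

On the amide-type nitrogen, tert-butyl in place of ethyl does not separate compound 3 from compound 2 in this assay (a number 6.7 percentage points higher from compound 2 to compound 3 (within the scatter)). For the compounds shown here, the new information lies in the wider comparison: tert-butyl in place of hydrogen gives the first step at this nitrogen to lie beyond the scatter (a number 13.3 percentage points higher from compound 1 to compound 3 (beyond the scatter)), though it remains modest. Substitution at this position can therefore make a measurable difference across the three compounds, even though neither step through ethyl does so alone.

Going by these compounds, whether a longer chain such as n-butyl or a phenyl group on this nitrogen would go further remains open. So does what a carboxylic acid or an amine in place of the amide would give, and whether the gap holds at other doses. Nothing available here explains the difference.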